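A few compounds are considered here, and "the series" means these few. Any claim that something is new, unique, unknown or untested is made for them only; others in the source may bear on it.

Values so far in an ADME assay on MT4 cells (Homo sapiens) for cytotoxicity, read by MTT assay, with a stated time of 96 h; on this read-out lower numbers stand for higher toxicity in this test and higher numbers for lower toxicity in this test:
Compound 1 `COc1ccc(-c2nc3cc(/C(C)=N/NC(N)=S)ccc3[nH]2)c(OC)c1` gives 72000 nM
Compound 2 `C/C(=N\NC(N)=S)c1ccc2c(c1)nc(-c1ccccc1)n2C1CCCCC1` gives 20000 nM
Compound 3 `C/C(=N\NC(N)=S)c1ccc2c(c1)nc(-c1ccc(C(F)(F)F)cc1)n2C1CCCCC1` gives 30000 nM

Compound 3 lies within the scatter of compound 2, while compound 1 stands higher, beyond the scatter of compound 3. The next compound is compound 4 `COc1ccc(-c2nc3cc(/C(C)=N/NC(N)=S)ccc3n2C2CCCCC2)c(OC)c1`, which carries 2,4-dimethoxyphenyl in place of 4-(trifluoromethyl)phenyl on an aromatic carbon.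

Among the compounds with values here, only one measured step concerns this aromatic ring: a 1.5-fold higher number from compound 2 to compound 3 (0.18 log units; within the scatter) stays within the scatter. Within the data shown here, compound 1 (72000 nM) shares the 2,4-dimethoxyphenyl group but has no cyclohexyl group, so no measured step isolates the incoming group. Its higher number widens the upper side of the expectation only. No step beyond the scatter is therefore expected in this assay, and the expected change is a 1.1-fold higher number from compound 3 to compound 4 (0.03 log units; within the scatter) in size. Compound 4 is estimated at 32000 nM (expected range 14000 nM to 75000 nM).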

Compound 4, half-maximal cytotoxic concentration: 17000 nM
Beside the measured number, compound 4's estimate is 1.9-fold (0.27 log units) above it; low and high end bracket the measured number.
By their numbers in this assay, from the lowest: compounds 4, 2 and 3 (each within the scatter of the next); then compound 1.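

In this assay, the group on the aromatic carbon between two ring nitrogen atoms now covers phenyl, 4-(trifluoromethyl)phenyl and 2,4-dimethoxyphenyl with no step beyond the scatter: a 1.8-fold lower number from compound 3 to compound 4 (0.25 log units; within the scatter) and a 1.2-fold lower number from compound 2 to compound 4 (0.07 log units; within the scatter). Within the data shown here, the one step here beyond the scatter lies at another place, with cyclohexyl in place of hydrogen on an aromatic nitrogen, which gives a 4.2-fold lower number from compound 1 to compound 4 (0.63 log units; beyond the scatter) while 2,4-dimethoxyphenyl stays constant. Nothing available explains either result.

Among these compounds, this pair is the only reading of the cyclohexyl change, so it remains open whether the step recurs with phenyl or 4-(trifluoromethyl)phenyl on the shared core. Also open, on these data alone, is how this read-out would respond to an amine or a carboxylic acid on the phenyl ring, or to an ethyl chain in place of cyclohexyl.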